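This account rests on a few compounds, and the source may have more. Where it says the series, first, only, none or still open, it means among the compounds named here.

Compound 3 has the structure `CCCCc1cn([C@@H]2O[C@@H]3COP(=O)(O)O[C@H]3[C@H]2O)c(=O)nc1N`. In a functional assay on L1210 cells (Mus musculus) for cytotoxicity (on this read-out lower numbers stand for stronger inhibition and higher numbers for weaker inhibition), compound 3 gives > 200 ug/mL, which is a limit of the assay rather than a measured number. Two other compounds share its core and differ only in the chain on the ring. Compound 1, `CCCCCCc1cn([C@@H]2O[C@@H]3COP(=O)(O)O[C@H]3[C@H]2O)c(=O)nc1N`, carries a hexyl chain; in this assay compound 1 gives > 200 ug/mL, again a limit. Compound 2, `CCc1cn([C@@H]2O[C@@H]3COP(=O)(O)O[C@H]3[C@H]2O)c(=O)nc1N`, carries an ethyl group; in this assay compound 2 gives > 200 ug/mL, also a limit. All three values stand together at the limit of > 200 ug/mL in this assay, at which 3 of the 3 values shown sit, and the steps between them therefore cannot be read: a step that the two limits leave unreadable from compound 1 to compound 2, a step that the two limits leave unreadable from compound 1 to compound 3 and a step that the two limits leave unreadable from compound 2 to compound 3 remain unreadable in size and direction.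

Compound 4 is the unmeasured member, `CC(C)c1cn([C@@H]2O[C@@H]3COP(=O)(O)O[C@H]3[C@H]2O)c(=O)nc1N`. Its difference from compound 3 is isopropyl in place of butyl on an aromatic carbon. Among the measured compounds shown here, no measured step offers a readable size to lean on: each change among compounds 1, 2 and 3 left the value at the same limit. Compound 4 is therefore expected to stay at that limit as well, with an expected step of a number no higher from compound 3 to compound 4 (the limit leaves the size open). The estimate for compound 4 is 200 ug/mL, with a range from 100 ug/mL to 400 ug/mL, and the most likely outcome is that this assay once more reports only a limit and no number.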

Compound 4, concentration for 50% inhibition: > 200 ug/mL
Compound 4: a limit, no number; the forecaster's own chance of this, stated with the estimate: 85%; the middle value sits exactly at the limit.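

In this assay compound 4 gives > 200 ug/mL, which is a limit and not a number. The steps linking compound 4 to compound 1, compound 2 and compound 3 therefore cannot be read, because all the values stand together: the limit of > 200 ug/mL in this assay, at which 4 of the 4 values shown sit.

The compounds shown leave open how strongly, if at all, any of these four chains inhibits the cells, and whether chain length or branching changes that.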